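Methylsulfanyl to ethylsulfanyl on the saturated ring of compound 2

The source may hold more compounds than are shown below. What is called first, only, known or untested is meant among the compounds shown, and "the series" means these compounds.

Going by the values given here, compound 2 `CSC1CN(c2ccccc2)NC1=O` sits at the higher end of the two numbers so far: in an assay on isolated protein for inhibition of Polyunsaturated fatty acid 5-lipoxygenase (Rattus norvegicus) (a higher number here means a weaker inhibitor, a lower number a stronger inhibitor), compound 2 gives 320 nM, while compound 1 `O=C1NN(c2ccccc2)CC1Cc1cccs1` gives 140 nM. Among the compounds with values here, the single step between them, a 2.3-fold higher number from compound 1 to compound 2 (0.36 log units; beyond the scatter), is modest and concerns exchange of the whole group on the saturated ring carbon. Compound 3 `CCSC1CN(c2ccccc2)NC1=O` differs from compound 2 only by methyl in place of hydrogen on a saturated chain carbon bound to a sulfur. Within the data shown here, no measured step touches a change of this kind; the one step on record, from compound 1 to compound 2, replaced a larger group and is at best an indirect guide. A one-carbon extension from methylsulfanyl to ethylsulfanyl is expected to move this assay little, if at all beyond the scatter, in either direction. Compound 3 is therefore estimated at 300 nM, with a range of 120 nM to 800 nM, corresponding to an expected step of a 1.1-fold lower number from compound 2 to compound 3 (0.03 log units; within the scatter).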

Compound 3, half-maximal inhibitory concentration: 60 nM
Compound 3: middle estimate off by 5.0-fold (0.70 log units), on the high side, and the stated range ends above it.
By their numbers in this assay, from the lowest: compound 3; then compound 1; then compound 2.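

In this assay, methyl in place of hydrogen on a saturated chain carbon bound to a sulfur gives a 5.3-fold lower number from compound 2 to compound 3 (0.73 log units; beyond the scatter), so this chain responds clearly to a change as small as methyl to ethyl, which compound 1 and compound 2 alone could not show. Exchanging the whole group of compound 1 for ethylsulfanyl gives a 2.3-fold lower number from compound 1 to compound 3 (0.37 log units; beyond the scatter), a step in the opposite direction from the one printed for methylsulfanyl against the same group. The sulfur-linked groups therefore fall on either side of compound 1, depending only on the chain. No measurement at hand accounts for the step from methylsulfanyl to ethylsulfanyl. As far as these compounds go, whether the lower numbers continue with a longer chain such as propylsulfanyl or butylsulfanyl, or hold with a branched isopropylsulfanyl or an ethoxy group, remains open.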